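A few compounds are considered here, and "the series" means these few. Any claim that something is new, unique, unknown or untested is made for them only; others in the source may bear on it.

Measured compounds:

Compound 1 `CCc1cccc(NC(=O)CSc2nc(Nc3ccccc3)c3ccccc3n2)c1`: 12400 nM
Compound 2 `COc1cccc(NC(=O)CSc2nc(Nc3ccccc3)c3ccccc3n2)c1`: 21700 nM
Compound 3 `O=C(CSc1nc(Nc2ccccc2)c2ccccc2n1)Nc1ccc(F)cc1`: 34100 nM

These three values come from a functional assay on MDA-MB-231 cells (Homo sapiens) for inhibition, read by MTT assay, with a stated time of 72 h; a higher number here means a weaker inhibitor, a lower number a stronger inhibitor. Among them compound 3 carries the highest number: its gap to compound 2 is within the scatter, while its gap to compound 1, a 2.8-fold higher number from compound 1 to compound 3 (0.44 log units; beyond the scatter), is modest but beyond it. Compound 4 `O=C(CSc1nc(Nc2ccccc2)c2ccccc2n1)Nc1ccc([N+](=O)[O-])cc1` is the next member, differing from compound 3 in one place: nitro in place of fluoro on an aromatic carbon.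

Among the measured compounds shown here, two measured steps touch the same ring on the amide-type nitrogen. Going from compound 1 to compound 3 gave a 2.8-fold higher number from compound 1 to compound 3 (0.44 log units; beyond the scatter), and from compound 2 to compound 3 a 1.6-fold higher number from compound 2 to compound 3 (0.20 log units; within the scatter), the second within the scatter. The remaining step, a 1.8-fold higher number from compound 1 to compound 2 (0.24 log units; within the scatter), also stayed within the scatter. For the measured compounds named here, no measured pair shows a nitro group, so the step to compound 4 in this assay rests on this thin record; a small step in either direction, or none beyond the scatter, is expected. Compound 4 is accordingly expected to give about 34000 nM, plausibly between 12000 nM and 100000 nM. This estimate corresponds to an expected step of a 1.0-fold lower number from compound 3 to compound 4 (0.00 log units; within the scatter).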

Compound 4, half-maximal inhibitory concentration: 16800 nM
Compound 4: middle estimate off by 2.0-fold (0.31 log units), on the high side; low and high end bracket the measured number.
By their numbers in this assay, from the lowest: compounds 1, 4, 2 and 3 (each within the scatter of the next, the first and the last beyond it).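

Among the compounds shown here, replacing fluoro with nitro on this aromatic carbon gave a 2.0-fold lower number from compound 3 to compound 4 (0.31 log units; beyond the scatter) in this assay and is the first step here that changes only the group at this carbon, showing that the number responds modestly to that group alone. Compound 4 also stands level with the compounds bearing their groups elsewhere on the ring, with a 1.3-fold lower number from compound 2 to compound 4 (0.11 log units; within the scatter) and a 1.4-fold higher number from compound 1 to compound 4 (0.13 log units; within the scatter) both within the scatter, so the 4-nitrophenyl group cannot be told apart from 3-methoxyphenyl or 3-ethylphenyl. Nothing measured here accounts for the step from fluoro to nitro.

As far as these compounds go, it remains open whether an amine or a carboxylic acid on this carbon would give a number nearer that of compound 3 or compound 4. Also open, from the compounds shown here alone, is how a nitro group would read where compound 1 carries its ethyl group.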